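Methoxy on the Pendant Phenyl: Expectation for Compound 4

This account rests on a few compounds, and the source may have more. Where it says the series, first, only, none or still open, it means among the compounds named here.

Compound 1 `O=C(Nc1nc2ccc(F)cc2s1)c1cn(-c2ccccc2)nc1-c1ccccc1` gives 5570 nM in a functional assay on U-87MG ATCC cells for cytotoxicity against U-87 MG (Homo sapiens), read by MTT assay, with a stated time of 72 h; a higher number here means a weaker inhibitor, a lower number a stronger inhibitor.
Compound 2 `O=C(Nc1nc2ccc(Cl)cc2s1)c1cn(-c2ccccc2)nc1-c1ccccc1` gives 4980 nM in this assay.
Compound 3 `Cc1ccc2nc(NC(=O)c3cn(-c4ccccc4)nc3-c3ccccc3)sc2c1` gives 23200 nM in this assay.

Compound 3 stands at the highest number of the three. The steps of a 4.2-fold higher number from compound 1 to compound 3 (0.62 log units; beyond the scatter) and a 4.7-fold higher number from compound 2 to compound 3 (0.67 log units; beyond the scatter) both lie beyond the scatter, so compound 3 is the weakest of the measured set. Compound 1 and compound 2 cannot be ordered against each other, since the step of a 1.1-fold lower number from compound 1 to compound 2 (0.05 log units; within the scatter) lies within the scatter.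

Compound 4 `COc1ccc(-c2nn(-c3ccccc3)cc2C(=O)Nc2nc3ccc(C)cc3s2)cc1` differs from compound 3 by methoxy in place of hydrogen on an aromatic carbon. None of the three measured steps concerns this ring: each of them exchanges the group on an aromatic carbon of the shared core, and the pendant phenyl is identical in compounds 1, 2 and 3. Going by the values given here, there is therefore no measured step that bears on the change from compound 3 to compound 4, and no basis in these data for expecting a shift in either direction.

The expected outcome is that compound 4 stays close to compound 3, with a step of about a 1.0-fold lower number from compound 3 to compound 4 (0.00 log units; within the scatter), no larger than the scatter. The estimate for compound 4 in this assay is 23000 nM, with a range from 8000 nM to 65000 nM.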

Compound 4, half-maximal inhibitory concentration: > 50000 nM
Compound 4: a limit, no number (the forecaster's own chance of this, stated with the estimate: 10%); middle value at least 2.1-fold (0.33 log units) away from the limit.
By their numbers in this assay, from the lowest: compounds 2 and 1 (each within the scatter of the next); then compound 3. At a limit, above all of these: compound 4.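

Going by these compounds alone, until compound 4, the pendant phenyl was identical in compound 1, compound 2 and compound 3, so this is the first reading of any change on that ring: phenyl to 4-methoxyphenyl, with methoxy entering on an aromatic carbon para to a large group. The change gives an at least 2.1-fold higher number from compound 3 to compound 4 (0.33 log units; beyond the scatter), which shows that this position is not indifferent to substitution in this assay and that methoxy here moves the result towards a weaker inhibitor. Compound 4 gives a limit and not a number, so the step has a lower bound but no measured size: the limit of > 50000 nM in this assay, at which 1 of the 4 values shown sits.

Methoxy is the only group shown at this position, and only on the methyl-bearing core of compound 3, so it remains open whether a smaller group such as fluoro, or a hydroxyl or an amine at the same place, would give a similar result. As far as these compounds go, it also remains open whether the same change would give a comparable step on the fluoro-bearing core of compound 1 or the chloro-bearing core of compound 2.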